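The source may hold more compounds than are shown below. What is called first, only, known or untested is meant among the compounds shown, and "the series" means these compounds.

Of the compounds shown here, three built on one shared core have been tested in an in vitro assay on CHO cells for displacement of a labelled ligand from Bombesin receptor subtype-3 (Homo sapiens), read by scintillation counting, with a stated time of 2 h; a lower number here means a stronger inhibitor, a higher number a weaker inhibitor. Compound 2 `CCC(C)(C)Cc1c[nH]c(CCc2ccc(-c3cccnc3)cc2)n1` gives 7.5 nM and stands lowest of the three numbers. Compound 1 `CCC(C)(C)Cc1c[nH]c(CCc2ccc(-c3cnccn3)cc2)n1` gives 51 nM, and compound 3 `CCC(C)(C)Cc1c[nH]c(CCc2ccc(-c3ccc(F)cn3)cc2)n1` gives 19 nM. The step of a 6.8-fold lower number from compound 1 to compound 2 (0.83 log units; beyond the scatter) is the largest change seen so far, while the steps of a 2.7-fold lower number from compound 1 to compound 3 (0.43 log units; beyond the scatter) and a 2.5-fold higher number from compound 2 to compound 3 (0.40 log units; beyond the scatter) are smaller; each comes from swapping one aromatic ring for another at the same carbon. Compound 4 `CCC(C)(C)Cc1c[nH]c(CCc2ccc(-n3cncn3)cc2)n1` has not yet been measured. It differs from compound 2 in this way: 1H-1,2,4-triazol-1-yl in place of pyridin-3-yl on an aromatic carbon. Among the measured compounds shown here, no measured step involves a five-membered ring, so the guidance is indirect. The steps of a 6.8-fold lower number from compound 1 to compound 2 (0.83 log units; beyond the scatter) and a 2.5-fold higher number from compound 2 to compound 3 (0.40 log units; beyond the scatter) show that exchanging the ring on this carbon moves the number by modest amounts in either direction, and compound 2 already holds the lowest value, so a modest rise beyond the scatter is expected, a 5.3-fold higher number from compound 2 to compound 4 (0.73 log units; beyond the scatter). Compound 4 is estimated at 40 nM, with a range from 12 nM to 130 nM.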

Compound 4, half-maximal inhibitory concentration: 340 nM
Compound 4: the middle estimate sits 8.5-fold (0.93 log units) below what was measured; measured number above the stated range.
By their numbers in this assay, from the lowest: compound 2; then compound 3; then compound 1; then compound 4.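

Until now, every ring on this aromatic carbon was six-membered, and the differences among them stayed modest. The 1H-1,2,4-triazol-1-yl ring, a five-membered aromatic ring with 3 hetero atoms, brings a 45-fold higher number from compound 2 to compound 4 (1.66 log units; beyond the scatter) and an 18-fold higher number from compound 3 to compound 4 (1.25 log units; beyond the scatter), both large, and even the closest comparison gives a 6.7-fold higher number from compound 1 to compound 4 (0.82 log units; beyond the scatter), so it has the highest number of the four in this assay. This swap changes ring size and hetero atom count together, and no measurement shown here explains the loss.

On these data alone, what remains open is whether ring size or the number of ring nitrogens matters more. A pyrazol-1-yl ring, a five-membered ring with two nitrogens, or a plain phenyl ring on this same carbon would help to separate those two changes.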